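Methyl Added to a Dicarboxylic Acid Indole Inhibitor

The compounds below may be only part of what the source reports. "The series", "measured", "known", "first", "only" and "open" are said of these compounds alone.

Of the compounds shown here, three have been measured in an assay on isolated protein for inhibition of Amine oxidase [flavin-containing] A (Homo sapiens), read by fluorescence and spectrophotometry, with a stated time of 20 min; a lower number here means a stronger inhibitor, a higher number a weaker inhibitor. Compound 1 `Cc1ccc(-c2cc3cc(C#N)c(C#N)cc3n2O)cc1` gives 1140 nM in this assay, and compound 2 `COc1ccc(-c2c(CO)c3cc(C#N)c(C#N)cc3n2OC)cc1` gives 1130 nM. Compound 3 `O=C(O)c1cc2cc(-c3ccccc3)n(O)c2cc1C(=O)O` stands highest of the three numbers: in this assay compound 3 gives 23300 nM, a value beyond the scatter from both compound 1 and compound 2, so compound 3 is the weakest inhibitor among those measured.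

Compound 4 `Cc1ccc(-c2cc3cc(C(=O)O)c(C(=O)O)cc3n2O)cc1` has not yet been measured. It differs from compound 3 in one place: methyl in place of hydrogen on an aromatic carbon, that is, a methyl in place of hydrogen on an aromatic carbon. For the measured compounds named here, no pair of measured compounds shows this single change on its own, so there is no measured step to lean on. A change of this small size is expected to move the number little in this assay, perhaps slightly downward, and most likely within the scatter. The step from compound 3 to compound 4 is therefore estimated at a 1.5-fold lower number from compound 3 to compound 4 (0.16 log units; within the scatter). For compound 4 the expected value in this assay is 16000 nM, with a range from 5000 nM to 50000 nM.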

Compound 4, half-maximal inhibitory concentration: > 100000 nM
Compound 4 ended at the assay's limit; the forecaster's own chance of this, stated with the estimate: 10%; at least 6.2-fold (0.79 log units) between middle value and limit.
By their numbers in this assay, from the lowest: compounds 2 and 1 (each within the scatter of the next); then compound 3. At a limit, above all of these: compound 4.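

In this assay, compound 4 stands at a limit of the assay, not at a number: the limit of > 100000 nM in this assay, at which 1 of the 4 values shown sits. For the compounds shown here, this gives the first measured step for a change at this position: phenyl to 4-methylphenyl, with a methyl para to a large group, yields an at least 4.2-fold higher number from compound 3 to compound 4 (0.63 log units; beyond the scatter). From the compounds shown here alone, a single added methyl on an aromatic carbon is therefore not a neutral change on this dicarboxylic acid compound, and the printed step is only a minimum, so the full size of the shift remains unknown.

The compounds shown leave open whether an amine or a longer chain such as ethyl at the same position would shift the number in the same direction. Going by these compounds alone, they also leave open whether the methyl would have a comparable effect with a nitrile in place of each carboxylic acid, as no pair shows that single change.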